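The source may hold more compounds than are shown below. What is called first, only, known or untested is meant among the compounds shown, and "the series" means these compounds.

Series notes. In an in vitro ADME assay on microsomes from liver (Mus musculus) for pharmacokinetics, read by LC-MS, with a stated time of 10 min, tested at 1 uM (on this read-out higher numbers stand for fast clearance and lower numbers for slow clearance), compound 1 `CN1C[C@H](C(=O)Nc2ccccc2)[C@@H](c2ccc(/C=C/C(=O)Nc3ccccc3N)cc2)C1` gives 67 mL/min/kg, compound 2 `CN1C[C@H](C(=O)Nc2ccc(C(F)(F)F)cc2)[C@@H](c2ccc(/C=C/C(=O)Nc3ccccc3N)cc2)C1` gives 23 mL/min/kg and compound 3 `COc1cccc(NC(=O)[C@H]2CN(C)C[C@@H]2c2ccc(/C=C/C(=O)Nc3ccccc3N)cc2)c1` gives 65 mL/min/kg. Among the three numbers compound 3 stands second highest; compound 1 sits within the scatter of it, while compound 2 is set apart by a 2.8-fold higher number from compound 2 to compound 3 (0.45 log units; beyond the scatter). The next step leads to compound 4 `CN1C[C@H](C(=O)Nc2ccc(Cl)cn2)[C@@H](c2ccc(/C=C/C(=O)Nc3ccccc3N)cc2)C1`, which differs from compound 3 by 5-chloropyridin-2-yl in place of 3-methoxyphenyl on an amide-type nitrogen. Going by the values given here, no measured step covers this change directly. The step of a 1.0-fold lower number from compound 1 to compound 3 (0.01 log units; within the scatter) shows that a substituent on this aryl ring can leave this assay unchanged, whereas a 2.9-fold lower number from compound 1 to compound 2 (0.46 log units; beyond the scatter) shows a modest lowering is possible. A small step, if any, is therefore expected, most likely downward: for compound 4 the estimated value is 45 mL/min/kg, with a range from 22 mL/min/kg to 90 mL/min/kg, corresponding to an expected 1.4-fold lower number from compound 3 to compound 4 (0.16 log units; within the scatter).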

Compound 4, clearance: 31 mL/min/kg
Beside the measured number, compound 4's estimate is 1.5-fold (0.16 log units) above it; the range from low to high includes it.
By their numbers in this assay, from the lowest: compounds 2 and 4 (each within the scatter of the next); then compounds 3 and 1 (each within the scatter of the next).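

In this assay, 5-chloropyridin-2-yl on the amide-type nitrogen gives a 2.2-fold lower number from compound 1 to compound 4 (0.33 log units; beyond the scatter) and a 2.1-fold lower number from compound 3 to compound 4 (0.32 log units; beyond the scatter) in this series, so a lower number at this position is not confined to the 4-(trifluoromethyl)phenyl ring. A ring with a hetero atom can therefore serve here, and the two substituted rings are not separated: a 1.3-fold higher number from compound 2 to compound 4 (0.13 log units; within the scatter) is the step between them.

Whether the chlorine or the ring nitrogen carries the step stays open, as plain pyridin-2-yl and 4-chlorophenyl are not among the compounds shown, and an amine or carboxylic acid on this ring is equally untested in these notes. No supporting data bear on the reason for these steps.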